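Compound 3 to compound 4: changing the two-ring group

The source may hold more compounds than are shown below. What is called first, only, known or untested is meant among the compounds shown, and "the series" means these compounds.

In a functional assay on BaF3 cells (Mus musculus) for antiproliferative activity (on this read-out higher numbers stand for an effect only at larger amounts of compound and lower numbers for an effect already at smaller amounts), compound 3 (`CCN1CCN(Cc2ccc(NC(=O)c3ccc(C)c(C#Cc4cnc5[nH]cnc5c4)c3)cc2C(F)(F)F)CC1`) gives 60 nM as the lowest of three numbers, with compound 1 (`CCN1CCN(Cc2ccc(NC(=O)c3ccc(C)c(C#Cc4ccc(NC(=O)C5CC5)nc4)c3)cc2C(F)(F)F)CC1`) at 1800 nM and compound 2 (`CCN1CCN(Cc2ccc(NC(=O)c3ccc(C)c(C#Cc4cnccn4)c3)cc2C(F)(F)F)CC1`) at 2490 nM on the same read-out. Compound 4 (`CCN1CCN(Cc2ccc(NC(=O)c3ccc(C)c(C#Cc4cnc5nccnc5c4)c3)cc2C(F)(F)F)CC1`) differs from compound 3 by a group of 10 heavy atoms (7 carbon, 3 nitrogen; one six-membered aromatic ring with 1 hetero atom, one six-membered aromatic ring with 2 hetero atoms) in place of a group of 9 heavy atoms (6 carbon, 3 nitrogen; one five-membered aromatic ring with 2 hetero atoms, one six-membered aromatic ring with 1 hetero atom), on a triple-bonded carbon and the entering group has 0 hydrogen-bond donors, where the leaving group has 1. Two large steps bear on this (a 30-fold lower number from compound 1 to compound 3 (1.48 log units; beyond the scatter) and a 42-fold lower number from compound 2 to compound 3 (1.62 log units; beyond the scatter)), whereas a 1.4-fold higher number from compound 1 to compound 2 (0.14 log units; within the scatter) stays within the scatter. Among the compounds with values here, no measured pair tests this swap directly. A move to a higher number is expected, estimated as a 3.3-fold higher number from compound 3 to compound 4 (0.52 log units; beyond the scatter) and smaller than a 42-fold lower number from compound 2 to compound 3 (1.62 log units; beyond the scatter) in size. For compound 4 the estimate is 200 nM (range 40 nM to 1000 nM).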

Compound 4, half-maximal effective concentration: 3320 nM
Estimate against measurement, compound 4: 17-fold (1.22 log units) below; the measured number lies above the stated range.
By their numbers in this assay, from the lowest: compound 3; then compounds 1, 2 and 4 (each within the scatter of the next).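

With a 55-fold higher number from compound 3 to compound 4 (1.74 log units; beyond the scatter) at this triple-bonded carbon, a two-ring group as such does not keep the low number of compound 3: a six-membered ring in place of the five-membered one, with 0 hydrogen-bond donors, loses it. With a 1.3-fold higher number from compound 2 to compound 4 (0.12 log units; within the scatter) and a 1.8-fold higher number from compound 1 to compound 4 (0.27 log units; within the scatter) both within the scatter, the group of compound 4 does no better than the one-ring groups. No measurement at hand explains the large step.

On these data alone, whether the hydrogen-bond donor or the ring size matters stays open. A methyl group on the ring nitrogen of compound 3, or an amino group on the entering group of compound 4, would separate the two.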